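Dechlorination of the aryl group in the thiazolidinone series

This account rests on a few compounds, and the source may have more. Where it says the series, first, only, none or still open, it means among the compounds named here.

Compound 1 `CCC1S/C(=N\N=C\c2c(-c3ccc(Cl)cc3)[nH]c3ccccc23)NC1=O` is the reference point. Within the data shown here, in an ADME assay on BJ cells (Homo sapiens) for cytotoxicity, read by fluorescence, with a stated time of 24 h (a lower number here means a stronger inhibitor, a higher number a weaker inhibitor), compound 1 gives 7450 nM, the lowest of the two numbers measured so far. Among the measured compounds shown here, compound 2 `C=CCN1C(=O)C(CC(=O)c2ccc(F)cc2)S/C1=N\N=C\c1ccccc1` gives 21500 nM in this assay, a higher number that lies beyond the scatter of the measurement; no single-change step connects these two compounds, so their values are simply noted side by side.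

Compound 3 `CCC1S/C(=N\N=C\c2c(-c3ccccc3)[nH]c3ccccc23)NC1=O` has not been measured. Relative to compound 1 the change is hydrogen in place of chloro on an aromatic carbon, hydrogen replacing chloro on an aromatic carbon of the 4-chlorophenyl group.

For the measured compounds named here, no measured step in this assay speaks to this change. Removing the chloro is expected to weaken cytotoxicity modestly; the step from compound 1 to compound 3 is estimated as a 1.6-fold higher number from compound 1 to compound 3 (0.21 log units; within the scatter), a small rise in the number, possibly not beyond the scatter. Compound 3 is therefore expected to give about 12000 nM in this assay, within a range of 4000 nM to 35000 nM.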

Compound 3, half-maximal inhibitory concentration: > 50000 nM
Compound 3 ended at the assay's limit (the forecaster's own chance of this, stated with the estimate: 15%); middle value at least 4.1-fold (0.61 log units) away from the limit.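

In this assay, among these compounds, hydrogen in place of chloro on an aromatic carbon gives an at least 6.7-fold higher number from compound 1 to compound 3 (0.82 log units; beyond the scatter), the first single-place step, and it shows that the number at this position responds to losing the chloro, para to a large group. Compound 3 stands at > 50000 nM, which is a limit of the assay and not a number. The step can therefore be read only as a lower bound, and its full size stays unknown: the limit of > 50000 nM in this assay, at which 1 of the 3 values shown sits.

The compounds shown leave open whether bromo, methoxy or an amine at this place would keep the number near that of compound 1 or let it rise to the limit. On these data alone, whether the same step holds on the core of compound 2 also remains open.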